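This account rests on a few compounds, and the source may have more. Where it says the series, first, only, none or still open, it means among the compounds named here.

Measured in a functional assay on the whole organism for activation, with Mus musculus as the target; on this read-out lower numbers stand for an effect already at smaller amounts and higher numbers for an effect only at larger amounts of compound:
- Compound 1 `Cc1nccn1-c1ccc(COc2cc(F)cc(C3(C(N)=O)CCOCC3)c2)cc1`: 4.9 mg/kg
- Compound 2 `Cc1nccn1-c1ccc(COc2cc(F)cc(C3(C(=O)N(C)C)CCOCC3)c2)cc1`: > 20 mg/kg

Compound 2 stands at > 20 mg/kg, which is a limit of the assay and not a number. Compound 3 `CCOC(=O)C1(c2cc(F)cc(OCc3ccc(-n4ccnc4C)cc3)c2)CCOCC1` carries ethoxy in place of dimethylamino on a carbonyl carbon. Among the compounds with values here, one measured step bears on this place: an at least 4.0-fold higher number from compound 1 to compound 2 (0.61 log units; beyond the scatter). It is at least modest, but it concerns amino, and only compound 1 at 4.9 mg/kg has that group. Ethoxy does not bring amino back, so no large change is expected. The expected change is an at least 1.1-fold lower number from compound 2 to compound 3 (0.04 log units; that floor lies within the scatter), which means no step beyond the scatter. For compound 3 the estimated value is 18 mg/kg, with an expected range from 6 mg/kg to 40 mg/kg.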

Compound 3, dose for half-maximal effect: 16 mg/kg
Compound 3: the middle estimate sits 1.1-fold (0.05 log units) above what was measured; the range from low to high includes it.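

In this assay, ethoxy on the carbonyl carbon, like dimethylamino before it, gives a higher number than amino, with a 3.3-fold higher number from compound 1 to compound 3 (0.51 log units; beyond the scatter). So two different replacements of amino, not just one, now move the number up. Against dimethylamino, ethoxy gives an at least 1.2-fold lower number from compound 2 to compound 3 (0.09 log units; that floor lies within the scatter), so no order can be claimed between them, because compound 2 sits at a limit and not at a number: the limit of > 20 mg/kg in this assay, at which 1 of the 3 values shown sits.

Still open, going by these compounds, is whether methylamino, with one methyl group on the nitrogen, would stay close to amino or behave like dimethylamino. A carboxylic acid, with hydroxy on the same carbonyl carbon, is equally untested here.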